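The source may hold more compounds than are shown below. What is called first, only, known or untested is meant among the compounds shown, and "the series" means these compounds.

Three measured compounds of this study share one core and differ in the aryl group on the triazole nitrogen. Compound 1 `N#CC1=C(N)Oc2c(c3nc4ccccc4nc3c3ccccc23)C12C(=O)N(Cc1cnnn1-c1cccc(Cl)c1)c1ccccc12` was tested in a functional assay on HepG2 cells (Homo sapiens) for antiproliferative activity, read by MTT assay, with a stated time of 48 h (a higher number here means a weaker inhibitor, a lower number a stronger inhibitor), and compound 1 gives > 50000 nM, which is a limit of the assay rather than a number. Compound 2 `Cc1ccc(C)c(-n2nncc2CN2C(=O)C3(C(C#N)=C(N)Oc4c3c3nc5ccccc5nc3c3ccccc43)c3ccccc32)c1` has 2,5-dimethylphenyl in place of 3-chlorophenyl on an aromatic nitrogen; in this assay compound 2 gives > 50000 nM, again a limit. The step that the two limits leave unreadable from compound 1 to compound 2 is therefore unreadable. Compound 3 `N#CC1=C(N)Oc2c(N)cc3nc4ccccc4nc3c2C12C(=O)N(Cc1cnnn1-c1ccc(Cl)cc1)c1ccccc12` is the third member; in this assay compound 3 gives > 50000 nM, a limit as well. Compound 3 thus stands at the limit of > 50000 nM in this assay, at which 3 of the 3 values shown sit, and no readable step exists among the measured compounds.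

Compound 4 `N#CC1=C(N)Oc2c(N)cc3nc4ccccc4nc3c2C12C(=O)N(Cc1cnnn1-c1ccc([N+](=O)[O-])cc1)c1ccccc12` differs from compound 3 by nitro in place of chloro on an aromatic carbon. Going by the values given here, no measured step bears on this change: the only step, from compound 1 to compound 2, is unreadable and concerns other substituents. Among the compounds with values here, because the limit of > 50000 nM in this assay, at which 3 of the 3 values shown sit, holds every value so far, the expectation for compound 4 is that the assay will again report only a limit. The step of a number no higher from compound 3 to compound 4 (the limit leaves the size open) is accordingly expected to be none beyond the scatter. Compound 4 is estimated at 50000 nM, within a range of 20000 nM to 50000 nM.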

Compound 4, half-maximal inhibitory concentration: > 50000 nM
Compound 4: a limit, no number; the forecaster's own chance of this, stated with the estimate: 85%; the middle value lies on the limit itself.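

In this assay compound 4 gives > 50000 nM, a limit of the assay and not a number. Compound 3 carries a limit too, so the change from compound 3 to compound 4 cannot be read as a step. The compounds shown leave open how their aryl groups rank against one another, since every result so far is the same: the limit of > 50000 nM in this assay, at which 4 of the 4 values shown sit.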